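Hydroxamic acid series: bromo to methyl on the aryl tail

The source may report more compounds than this note shows. Statements on the series, on what has been measured and on what is new or still open speak of the compounds shown alone.

Of the compounds shown here, three have been measured in a functional assay on MDA-MB-231 cells (Homo sapiens) for inhibition, read by sulforhodamine B assay; a higher number here means a weaker inhibitor of growth, a lower number a stronger inhibitor of growth. Compound 1 `O=C(CCC1=CCN(CCCc2ccc(Br)cc2)C1=O)NO` gives 2210 nM in this assay. Compound 2 `O=C(CCC1=CCN(Cc2cccc(Br)c2)C1=O)NO` gives 1990 nM, which stands within the scatter of compound 1. Compound 3 `N#Cc1ccc(CN2CC=C(CCC(=O)NO)C2=O)cc1` gives 5380 nM, the highest number of the three and beyond the scatter from compound 1. Compound 1 therefore holds the second highest number of the set, sitting close to compound 2 and well apart from compound 3.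

Compound 4 `Cc1ccc(CCCN2CC=C(CCC(=O)NO)C2=O)cc1` has not yet been measured. It differs from compound 1 by methyl in place of bromo on an aromatic carbon, the change sitting on an aromatic carbon of a six-membered aromatic ring of carbon only, para to a large group. Among the compounds with values here, no measured pair shows this change, so its size is unknown here. A small step is expected, likely none beyond the scatter, in either direction. Compound 4 is estimated at 2500 nM in this assay, with a range of 1100 nM to 5600 nM, meaning an expected step of a 1.1-fold higher number from compound 1 to compound 4 (0.05 log units; within the scatter).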

Compound 4, concentration for 50% growth inhibition: 2210 nM
Beside the measured number, compound 4's estimate is 1.1-fold (0.05 log units) above it; the range from low to high includes it.
By their numbers in this assay, from the lowest: compounds 2, 1 and 4 (each within the scatter of the next); then compound 3.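

In this assay, within the data shown here, the change from 4-bromophenyl to 4-methylphenyl gives no change at the digits printed from compound 1 to compound 4 (within the scatter), the first step that isolates a change in one place. At this aromatic carbon, para to a large group, bromo is therefore not required to keep the growth-inhibition number of compound 1, as methyl serves equally well in this one pair. Nothing on hand accounts for this flat step.

The compounds shown leave open whether this position tolerates groups of a different kind, such as an amine, a carboxylic acid or a longer chain in place of methyl. They also leave open whether plain hydrogen at this carbon would hold the number, which would show whether any group is needed here at all.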